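Hydroxy to Carboxy: What to Expect for Compound 4

A few compounds are considered here, and "the series" means these few. Any claim that something is new, unique, unknown or untested is made for them only; others in the source may bear on it.

Measured in a functional assay, read by spectrophotometry, with a stated time of 3 min (on this read-out lower numbers stand for stronger inhibition and higher numbers for weaker inhibition), so far:
compound 1 `Cc1ccc2[nH]c(=O)c(/C=N/c3ccc(O)cc3)cc2c1` gives 5240 nM
compound 2 `O=c1[nH]c2ccccc2cc1/C=N/c1ccc(O)cc1` gives 7150 nM
compound 3 `Cc1ccc2[nH]c(=O)c(/C=N/O)cc2c1` gives 38900 nM

Compound 2 holds the second highest number of the three. Its nearest neighbour is compound 1, whose number is within the scatter of it, so the two are not told apart; compound 3 lies beyond the scatter on the weaker side. Compound 4 `O=C(O)c1ccc(/N=C/c2cc3ccccc3[nH]c2=O)cc1` differs from compound 2 in one place: carboxy in place of hydroxy on an aromatic carbon.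

Going by the values given here, no measured step touches this exact change. The step of a 1.4-fold higher number from compound 1 to compound 2 (0.13 log units; within the scatter) concerns a methyl on the shared core, not the hydroxyphenyl, and is within the scatter. The step of a 7.4-fold higher number from compound 1 to compound 3 (0.87 log units; beyond the scatter) removes the whole 4-hydroxyphenyl and gives a modest loss, showing that this part of the molecule matters, but it says nothing about exchanging one small group for another there. Among the compounds with values here, with no direct precedent, the expected step of a 1.0-fold lower number from compound 2 to compound 4 (0.01 log units; within the scatter) is none beyond the scatter, with a wide margin either way. Compound 4 is therefore estimated at 7000 nM, between 2000 nM and 25000 nM.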

Compound 4, half-maximal inhibitory concentration: 438000 nM
For compound 4 the middle estimate is 63-fold (1.80 log units) below the measured one, outside the stated range (above it).
By their numbers in this assay, from the lowest: compounds 1 and 2 (each within the scatter of the next); then compound 3; then compound 4.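

In this assay carboxy in place of hydroxy on the aromatic carbon para to a large group gives a 61-fold higher number from compound 2 to compound 4 (1.79 log units; beyond the scatter) and so a large loss of inhibition, which shows that exchanging one small group at this place can matter a great deal. This is larger than the earlier step of a 7.4-fold higher number from compound 1 to compound 3 (0.87 log units; beyond the scatter) in which the whole 4-hydroxyphenyl gives way to hydroxy, and that step gave no hint that so small an exchange could weigh so heavily. No supporting data are available to explain the size of this loss.

Going by these compounds, whether an amine, a methoxy or a methyl ester at this place would behave like hydroxy or like carboxy stays open. On these data alone, it is also open whether the methyl on the shared core would alter the effect of carboxy.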